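A few compounds are considered here, and "the series" means these few. Any claim that something is new, unique, unknown or untested is made for them only; others in the source may bear on it.

Measured compounds in a functional assay (muscle tissue) with Cavia porcellus as the target; on this read-out higher numbers stand for an effect only at larger amounts of compound and lower numbers for an effect already at smaller amounts:
compound 1 `COC(=O)C1=C(C)N=C(C)/C(=C(\O)OC)C1c1ccc(F)cc1`, 129 nM
compound 2 `COC(=O)C1=C(C)N=C(C)/C(=C(\O)OC)C1c1ccc(C#N)cc1`, 3470 nM
compound 3 `CCOc1ccccc1C1C(C(=O)OC)=C(C)N=C(C)/C1=C(\O)OC`, 110 nM

Compound 3 gives the lowest of the three numbers, but compound 1 lies within the scatter of it, so the two cannot be separated; compound 2 alone lies beyond the scatter of both. Within the data shown here, the only single-point step measured so far is a 27-fold higher number from compound 1 to compound 2 (1.43 log units; beyond the scatter), a swap of the group on the aromatic carbon that has nothing to do with the ethoxy group of compound 3.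

Compound 4 `COC(=O)C1=C(C)N=C(C)/C(=C(\O)OC)C1c1ccccc1OC` differs from compound 3 by hydrogen in place of methyl on a saturated chain carbon bound to an oxygen on an aromatic ring, ethoxy to methoxy. Among the measured compounds shown here, no measured step touches the ethoxy group, so the data give no direct guide; the change removes one carbon and nothing else, and the closest comparison, compound 1 against compound 3, shows two small aromatic substituents giving numbers within the scatter of each other. For compound 4 the expected step is therefore a 1.2-fold higher number from compound 3 to compound 4 (0.07 log units; within the scatter), not beyond the scatter. Compound 4 is estimated at 130 nM, with a range from 50 nM to 350 nM.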

Compound 4, half-maximal effective concentration: 57.5 nM
Beside the measured number, compound 4's estimate is 2.3-fold (0.35 log units) above it; low and high end bracket the measured number.
By their numbers in this assay, from the lowest: compounds 4, 3 and 1 (each within the scatter of the next, the first and the last beyond it); then compound 2.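

In this assay ethoxy to methoxy on a saturated chain carbon bound to an oxygen on an aromatic ring gives a 1.9-fold lower number from compound 3 to compound 4 (0.28 log units; within the scatter) and so stays within the scatter, the first sign that this chain can lose one carbon without a clear shift. Exchanging the whole aromatic group matters more: 2-methoxyphenyl in place of 4-fluorophenyl on a saturated ring carbon gives a 2.2-fold lower number from compound 1 to compound 4 (0.35 log units; beyond the scatter) as a modest step beyond the scatter, while 2-methoxyphenyl in place of 4-cyanophenyl gives a 60-fold lower number from compound 2 to compound 4 (1.78 log units; beyond the scatter) as a large one. No evidence at hand accounts for these steps.

Open, on these data alone, is whether a longer chain such as propoxy, or a hydroxy group or an amine in place of the alkoxy group, would also stay within the scatter. Also open, as far as these compounds go, is how an unsubstituted phenyl group compares with 2-methoxyphenyl on the same core.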